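This account rests on a few compounds, and the source may have more. Where it says the series, first, only, none or still open, it means among the compounds named here.

Measured so far:
compound 1, `O=C(/C=C/c1ccc(OCc2ccccc2)cc1)c1ccccc1`, in a functional assay on HCT-116 cells (Homo sapiens) for antiproliferative activity, read by sulforhodamine B assay, with a stated time of 3 days, tested at 50 uM (a lower number here means a weaker effect, a higher number a stronger effect of the compound at the concentration tested), compound 1 gives 49.5%.
compound 2, `COc1cccc(/C=C/C(=O)c2ccc(OCc3ccccc3)cc2)c1`, in this assay compound 2 gives 76%.

Compound 2 stands highest of the two numbers; its nearest neighbour, compound 1, sits lower by a gap beyond the usual scatter.

Compound 3, `COc1ccc(/C=C/C(=O)c2ccc(OCc3ccccc3)cc2)cc1`, has not been measured. It differs from compound 2 in one place: 4-methoxyphenyl in place of 3-methoxyphenyl on a double-bonded chain carbon bound to a double-bonded chain carbon. Within the data shown here, no pair measured so far shows a step of this kind, so the size of the change is unknown; a small shift in this assay, downward or none beyond the scatter, is expected.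

Compound 3 is estimated at 68%, with a likely range of 45% to 88%. This expectation means a step of a number 8 percentage points lower from compound 2 to compound 3 (within the scatter).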

Compound 3, a percentage reported as inhibition, at one concentration (the size of the read-out at that concentration, not a potency): 13.2%
For compound 3 the middle estimate is 54.8 percentage points above the measured one; the whole stated range lies above it.
By their numbers in this assay, from the lowest: compound 3; then compound 1; then compound 2.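

In this assay, 4-methoxyphenyl in place of 3-methoxyphenyl on a double-bonded chain carbon bound to a double-bonded chain carbon means a large step of a number 62.8 percentage points lower from compound 2 to compound 3 (beyond the scatter). The two groups match in heavy atoms, hydrogen-bond donors and acceptors, so these counts do not separate the two compounds; only the arrangement of the same atoms differs. Nothing at hand explains the size of this step. Still open, on these data alone, is how a phenyl carrying a hydroxyl or an amine would read out at this place. Also open, as far as these compounds go, is whether the same exchange gives a step of similar size on another core.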